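Shortening the Amine Chain: From Compound 2 to Compound 3

The source may hold more compounds than are shown below. What is called first, only, known or untested is meant among the compounds shown, and "the series" means these compounds.

Measured so far:
compound 1, `CN(C)c1nc2c(ncn2-c2ccccc2)c(=O)n1-c1ccccc1`: 83800 nM
compound 2, `CCCCCN(CCCCC)c1nc2c(ncn2-c2ccccc2)c(=O)n1-c1ccc(Cl)cc1`: 10600 nM

In a functional assay on KB cells (Homo sapiens) for cytotoxicity, read by MTT assay, with a stated time of 72 h (a higher number here means a weaker inhibitor, a lower number a stronger inhibitor), compound 2 holds the lower of the two numbers, and compound 1 sits higher by a gap beyond the usual scatter. Compound 3, `CNc1nc2c(ncn2-c2ccccc2)c(=O)n1-c1ccc(Cl)cc1`, differs from compound 2 in one place: methylamino in place of dipentylamino on an aromatic carbon. With the smaller amino group, compound 3 is expected to move toward compound 1, which gives 83800 nM. The step from compound 2 to compound 3 is therefore estimated as a rise, a 4.2-fold higher number from compound 2 to compound 3 (0.63 log units; beyond the scatter). For compound 3 the expected value is 45000 nM, within a range from 12000 nM to 150000 nM.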

Compound 3, half-maximal inhibitory concentration: > 100000 nM
Compound 3 gave a limit, no number; the forecaster's own chance of this, stated with the estimate: 10%; at least 2.2-fold (0.34 log units) between middle value and limit.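

Compound 1 and compound 2 differ in more than one place, so they could not isolate the amine. Here, with the 4-chlorophenyl group kept, methylamino in place of dipentylamino gives an at least 9.4-fold higher number from compound 2 to compound 3 (0.97 log units; beyond the scatter), showing that the amine at this position alone changes the result. In this assay compound 3 gives > 100000 nM, which is a limit of the assay and not a number.

The change also adds a hydrogen-bond donor, so the compounds shown do not separate chain size from that donor. Going by these compounds, how a dipropylamino group would read at this position remains open.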